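Ester-to-acid step in a cinnamate series

The compounds below may be only part of what the source reports. "The series", "measured", "known", "first", "only" and "open" are said of these compounds alone.

Measured compounds:
compound 1, `CCOC(=O)/C=C/c1cc(Cl)ccc1OC(=O)c1nc(C)c(C)nc1C`: 67100 nM
compound 2, `CCOC(=O)/C=C/c1ccccc1OC(=O)c1nc(C)c(C)nc1C`: 110000 nM

For the measured compounds named here, in a functional assay on a cell-free system (Platelet, plasma, Oryctolagus cuniculus) for inhibition, with a stated time of 5 min, at 37 degrees C (a higher number here means a weaker inhibitor, a lower number a stronger inhibitor), compound 2 stands highest of the two numbers, with compound 1 nearest; the only measured step is a 1.6-fold higher number from compound 1 to compound 2 (0.21 log units; within the scatter), which changes a different part of the structure and lies within the scatter. Compound 3, `Cc1nc(C)c(C(=O)Oc2ccccc2/C=C/C(=O)O)nc1C`, differs from compound 2 by hydrogen in place of ethyl on an oxygen next to a carbonyl group. Going by the values given here, no measured step bears on this change, so no direction is taken from the data; the step from compound 2 to compound 3 is expected to be no change at the digits printed from compound 2 to compound 3 (within the scatter), with a wide range. Compound 3 is therefore estimated at 110000 nM, between 30000 nM and 400000 nM.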

Compound 3, half-maximal inhibitory concentration: 9600 nM
Beside the measured number, compound 3's estimate is 11-fold (1.06 log units) above it, outside the stated range (below it).
By their numbers in this assay, from the lowest: compound 3; then compounds 1 and 2 (each within the scatter of the next).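

Going from ethoxycarbonyl to carboxy gives an 11-fold lower number from compound 2 to compound 3 (1.06 log units; beyond the scatter) in this assay and is the first step in the series beyond the scatter. The chloro to hydrogen change gave only a 1.6-fold higher number from compound 1 to compound 2 (0.21 log units; within the scatter) and so did not separate its two compounds, which leaves the ethyl on this oxygen as the first place shown to matter. Nothing given here explains the size of this step.

Still open, from the compounds shown here alone, is whether the lower number holds for a carboxy compound carrying the chloro of compound 1. Also open, going by these compounds, is how a primary amide or a methyl ester at this position would compare.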